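Side chain at the amino acid carbon: hydroxy to a larger group

The source may hold more compounds than are shown below. What is called first, only, known or untested is meant among the compounds shown, and "the series" means these compounds.

Compound 1 `C[C@@H](O)[C@H](NC(=O)CN(c1nc(Cl)nc2[nH]cnc12)C1CC1)C(=O)O` gives 35.9% in a functional assay on the whole organism (Tail, strain ICR) with Mus musculus as the target, in the tail flick test, with a stated time of 90 min, at a dose of 25 umol/kg by the oral route; on this read-out lower numbers stand for a weaker effect and higher numbers for a stronger effect at the one dose given.
Compound 2 `O=C(O)CC[C@H](NC(=O)CN(c1nc(Cl)nc2[nH]cnc12)C1CC1)C(=O)O` gives 44.7% in this assay.
Compound 3 `O=C(CN(c1nc(Cl)nc2[nH]cnc12)C1CC1)N[C@@H](CO)C(=O)O` gives 43.9% in this assay.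

All three share the same core and differ only in the side chain of the amino acid part. Compound 3 has the second highest of the three numbers in this assay; its nearest neighbour is compound 2, with a number 0.8 percentage points lower from compound 2 to compound 3 (within the scatter), and its furthest is compound 1, with a number 8 percentage points higher from compound 1 to compound 3 (within the scatter). Neither gap goes beyond the scatter, so the three compounds cannot be ranked.

Compound 4 `N=C(N)NCCC[C@H](NC(=O)CN(c1nc(Cl)nc2[nH]cnc12)C1CC1)C(=O)O` carries the change (a group of 6 heavy atoms (3 carbon, 3 nitrogen; no ring) in place of one oxygen atom, on a saturated chain carbon, two bonds along the chain from an amide-type nitrogen and a carbonyl carbon). This is the same place that was altered between compound 2 and compound 3, where a carboxymethyl replaced a hydroxy and gave a number 0.8 percentage points lower from compound 2 to compound 3 (within the scatter); the step of a number 8.8 percentage points higher from compound 1 to compound 2 (within the scatter) also exchanged side chains at this position. Both stayed within the scatter. A change at this position is therefore expected to give a number 0.1 percentage points higher from compound 3 to compound 4 (within the scatter), a step not beyond the scatter. Compound 4 is estimated at 44%, with a range from 28% to 60%.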

Compound 4, a percentage reported as activity, at one dose (the size of the read-out at that dose, not a potency): 27.6%
Compound 4: the middle estimate sits 16.4 percentage points above what was measured, and the stated range ends above it.
By their numbers in this assay, from the lowest: compounds 4, 1, 3 and 2 (each within the scatter of the next, the first and the last beyond it).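

This position now shows a side chain change that goes beyond the scatter in this assay: the group of 6 heavy atoms (3 carbon, 3 nitrogen) in place of hydroxy gives a number 16.3 percentage points lower from compound 3 to compound 4 (beyond the scatter), and the same group measured against the 2-carboxyethyl side chain gives a number 17.1 percentage points lower from compound 2 to compound 4 (beyond the scatter). The side chain here can therefore matter, which the first three compounds did not reveal, although a number 8.3 percentage points lower from compound 1 to compound 4 (within the scatter) keeps compound 4 within reach of the 1-hydroxyethyl side chain. Nothing at hand explains the loss.

As far as these compounds go, what remains open is whether the loss goes with the nitrogen atoms of the new group or with the length of its carbon chain. A plain amine on a chain of the same length would help separate the two.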